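The source may hold more compounds than are shown below. What is called first, only, known or untested is meant among the compounds shown, and "the series" means these compounds.

Measured in a physicochemical assay for solubility, read by HPLC, in phosphate buffer, at pH 6.5; on this read-out lower numbers stand for lower solubility and higher numbers for higher solubility:
- compound 1 `COC(=O)C1=C(CN2CC3CC2CO3)NC(c2nccs2)=NC1(C)c1ccc(F)cc1`: 564 ug/mL
- compound 2 `COC(=O)C1=C(CN2CCC(O)C2)NC(c2nccs2)=NC1(C)c1ccc(F)cc1`: 503 ug/mL
- compound 3 `COC(=O)C1=C(Cn2ccnc2)NC(c2nccs2)=NC1(C)c1ccc(F)cc1`: 338 ug/mL

Compound 3 stands within the scatter of both other compounds, as shown by a 1.5-fold lower number from compound 2 to compound 3 (0.17 log units; within the scatter) and a 1.7-fold lower number from compound 1 to compound 3 (0.22 log units; within the scatter). The next compound is compound 4 `COC(=O)C1=C(CN(C)C2(C(=O)O)CC2)NC(c2nccs2)=NC1(C)c1ccc(F)cc1`, whose structural change is a group of 8 heavy atoms (5 carbon, 1 nitrogen, 2 oxygen; one three-membered non-aromatic ring of carbon only) in place of a group of 5 heavy atoms (3 carbon, 2 nitrogen; one five-membered aromatic ring with 2 hetero atoms), on a saturated chain carbon bound to a double-bonded ring carbon.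

The measured steps at this place bear on the change. Besides the two above, there is a 1.1-fold lower number from compound 1 to compound 2 (0.05 log units; within the scatter). All three lie within the scatter, across the three groups measured here. None of these compounds carries the three-membered non-aromatic ring of carbon only, so the steps are indirect evidence, and the range is kept wide.

No step beyond the scatter is expected in this assay. The expected size is a 1.6-fold higher number from compound 3 to compound 4 (0.21 log units; within the scatter).

The estimate for compound 4 is 550 ug/mL, with an expected range of 200 ug/mL to 1500 ug/mL.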

Compound 4, solubility: > 510 ug/mL
Compound 4: only a limit was reported (the forecaster's own chance of this, stated with the estimate: 10%); the middle value is on the limit's open side.
By their numbers in this assay, from the lowest: compounds 3, 2 and 1 (each within the scatter of the next).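

In this assay, compound 4 is reported only as a limit, not a number: the limit of > 510 ug/mL in this assay, at which 1 of the 4 values shown sits.

Against the other compounds this gives only floors, an at least 1.5-fold higher number from compound 3 to compound 4 (0.17 log units; that floor lies within the scatter) and an at least 1.0-fold higher number from compound 2 to compound 4 (0.00 log units; that floor lies within the scatter), and the step from compound 1 cannot be read. What is new is that this position on the saturated chain carbon, so far shown with three ring-bearing groups of 5 to 7 heavy atoms, now carries a group of 8 heavy atoms with a three-membered ring of carbon only, and the result still sits at the assay's limit rather than at a readable number.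

On these data alone, whether any step to compound 4 lies beyond the scatter stays open, as the floors do not settle it. Also open, as far as these compounds go, is how a primary amine, an amide or a longer chain bearing the carboxylic acid would read at this position.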